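The source may hold more compounds than are shown below. What is called first, only, known or untested is meant among the compounds shown, and "the series" means these compounds.

Working notes on the series. Three compounds sharing one core have numbers in a functional assay on K562 cells (Homo sapiens) for cytotoxicity, read by sulforhodamine B assay; on this read-out lower numbers stand for stronger inhibition of growth and higher numbers for weaker inhibition of growth. Here compound 1 `CC1=CC[C@@H]([C@@](C)(O)CCCC(C)(C)NC(=S)N/N=C\c2ccccc2)CC1` gives 20900 nM and compound 2 `COc1ccc(/C=N\NC(=S)NC(C)(C)CCC[C@](C)(O)[C@@H]2CC=C(C)CC2)cc1` gives 34900 nM, so compound 2 stands level with compound 1 within the scatter. Compound 3 `CC1=CC[C@@H]([C@@](C)(O)CCCC(C)(C)NC(=S)N/N=C\c2cccc([N+](=O)[O-])c2)CC1` gives 560 nM, well apart from both.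

The step under consideration leads from compound 2 to compound 4 `CC1=CC[C@@H]([C@@](C)(O)CCCC(C)(C)NC(=S)N/N=C\c2cccc(Cl)c2)CC1`, with 3-chlorophenyl in place of 4-methoxyphenyl on a carbon with a double bond to nitrogen.

Among the measured compounds shown here, three measured steps bear on it. The methoxy exchange gave a 1.7-fold higher number from compound 1 to compound 2 (0.22 log units; within the scatter), so losing the methoxy alone is expected to count for little. The nitro exchange gave a 37-fold lower number from compound 1 to compound 3 (1.57 log units; beyond the scatter), and the change closest to the one proposed gave a 62-fold lower number from compound 2 to compound 3 (1.79 log units; beyond the scatter). For the measured compounds named here, both are large, but both rest on compound 3 alone, and no chlorine-bearing compound has been measured. Some of that shift is expected to carry over to the 3-chlorophenyl compound, though probably not all of it, so a step beyond the scatter towards a lower number is expected in this assay.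

The expected step is an 8.7-fold lower number from compound 2 to compound 4 (0.94 log units; beyond the scatter). For compound 4 the estimated value is 4000 nM, with an expected range of 700 nM to 20000 nM.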

Compound 4, concentration for total growth inhibition: 1060 nM
Estimate against measurement, compound 4: 3.8-fold (0.58 log units) above, and the stated range covers the measured number.
By their numbers in this assay, from the lowest: compounds 3 and 4 (each within the scatter of the next); then compounds 1 and 2 (each within the scatter of the next).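

In this assay the large drop no longer hangs on compound 3 alone: 3-chlorophenyl in place of 4-methoxyphenyl on a carbon with a double bond to nitrogen shows (a 33-fold lower number from compound 2 to compound 4 (1.52 log units; beyond the scatter)), and the exchange that brings in the chloro group alone shows (a 20-fold lower number from compound 1 to compound 4 (1.29 log units; beyond the scatter)), both large steps. Chloro in place of nitro on an aromatic carbon stays within the scatter (a 1.9-fold higher number from compound 3 to compound 4 (0.28 log units; within the scatter)), so two different groups, nitro and chloro, both set their compounds apart from compounds 1 and 2. Across these four compounds the split runs between 3-nitrophenyl and 3-chlorophenyl on one side and phenyl and 4-methoxyphenyl on the other, and none goes against it, though each side holds only two compounds.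

Going by these compounds, whether the group itself or its place on the ring decides the number stays open: a 4-chlorophenyl and a 3-methoxyphenyl compound would separate the two, and a 3-aminophenyl or 3-carboxyphenyl compound would test how far the split extends. Nothing shown here bears on why these steps fall as they do.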